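Chain change at the aromatic nitrogen: compound 2 to compound 3

The compounds below may be only part of what the source reports. "The series", "measured", "known", "first", "only" and "open" are said of these compounds alone.

Of the compounds shown here, two have been measured. Compound 1 `CCCN1CCCN(c2nc3ccccc3n2CCOCC)CC1` gives 8.4 nM in a functional assay on ileum for inhibition of histamine H1 receptor (Cavia porcellus); on this read-out higher numbers stand for weaker inhibition and lower numbers for stronger inhibition. Compound 2 `CCCCCCCn1c(N2CCN(C)CC2)nc2ccccc21` gives 150 nM in this assay, the higher of the two numbers and beyond the scatter from compound 1. Compound 3 `CCCC(C)Cn1c(N2CCN(C)CC2)nc2ccccc21` is not yet measured; it differs from compound 2 by 1-methylbutyl in place of hexyl on a saturated chain carbon bound to an aromatic nitrogen. Within the data shown here, no measured pair shows how a change at this place moves the number, so no step beyond the scatter is expected, and the expected step is no change at the digits printed from compound 2 to compound 3 (within the scatter). Compound 3 is therefore estimated at 150 nM, within a range from 50 nM to 450 nM.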

Compound 3, half-maximal inhibitory concentration: 500 nM
The estimate for compound 3 lay 3.3-fold (0.52 log units) below the measured number, outside the stated range (above it).
By their numbers in this assay, from the lowest: compound 1; then compound 2; then compound 3.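

The saturated chain carbon bound to an aromatic nitrogen is a place where a change of chain moves the number: 1-methylbutyl in place of hexyl gives a 3.3-fold higher number from compound 2 to compound 3 (0.52 log units; beyond the scatter) in this assay and thus weaker inhibition. This single step combines branching with a chain of 5 carbon instead of 6, so the two cannot be separated. Nothing at hand accounts for the step.

On these data alone, whether an unbranched pentyl chain, a longer chain such as octyl, or an amine on the chain would move the number stays open. As far as these compounds go, compound 1 differs from both compounds in more than one place, so the part this position plays in its lower number also stays open.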